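A few compounds are considered here, and "the series" means these few. Any claim that something is new, unique, unknown or untested is made for them only; others in the source may bear on it.

Series notes. The shared core is that of compound 1 `N=C(S)CCCn1nc(-c2ccccc2)ccc1=O`; compound 2 `CC(CC(=N)S)n1ncccc1=O` carries the same ring without the phenyl group and with a shorter, branched chain. Among the measured compounds shown here, in a functional assay on the whole organism (stomach) with Rattus norvegicus as the target (a lower number here means that less compound is needed, a higher number that more compound is needed for the effect), compound 1 gives 31.9 mg/kg, the only number on record in this assay. Compound 2 reaches only a limit of this assay, > 100 mg/kg, so no number stands for it. For the measured compounds named here, compound 1 therefore stands alone as the single measured value, while the limit of > 100 mg/kg in this assay, at which 1 of the 2 values shown sits, applies to compound 2.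

Compound 3 `C/N=C(/S)CCCCCn1nc(-c2ccccc2)ccc1=O` is not yet measured. It differs from compound 1 in a group of 6 heavy atoms (4 carbon, 1 nitrogen, 1 sulfur; no ring) in place of a group of 3 heavy atoms (1 carbon, 1 nitrogen, 1 sulfur; no ring), on a saturated chain carbon, three bonds along the chain from an aromatic nitrogen. Going by the values given here, no measured step covers this kind of change, so the expected step from compound 1 to compound 3 in this assay is a 1.1-fold higher number from compound 1 to compound 3 (0.04 log units; within the scatter), not beyond the scatter in either direction. Compound 3 is estimated at 35 mg/kg, with a range from 12 mg/kg to 100 mg/kg.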

Compound 3, dose for half-maximal effect: 25.2 mg/kg
Estimate against measurement, compound 3: 1.4-fold (0.14 log units) above; the range from low to high includes it.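

Working notes on the chain. In this assay placing a group of 6 heavy atoms (4 carbon, 1 nitrogen, 1 sulfur; no ring) in place of a group of 3 heavy atoms (1 carbon, 1 nitrogen, 1 sulfur; no ring), on a saturated chain carbon, three bonds along the chain from an aromatic nitrogen, gives a 1.3-fold lower number from compound 1 to compound 3 (0.10 log units; within the scatter) and so this position accepts the larger group with no step beyond the scatter. The same step also takes the group from 2 hydrogen-bond donors to 1 hydrogen-bond donor, and the two compounds still cannot be told apart in this read-out. No measurement shown bears on why the step stays this small.

Going by these compounds, a longer chain, or an amine or a carboxylic acid in place of the group of 6 heavy atoms, remains open. On these data alone, compound 2 gives only a limit of the assay at > 100 mg/kg and differs from compound 1 in more than one place, so the part played by the phenyl group also stays open.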